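A few compounds are considered here, and "the series" means these few. Any claim that something is new, unique, unknown or untested is made for them only; others in the source may bear on it.

Among the compounds with values here, compound 2 `Cc1ccccc1/C=C/C(=O)NNC(=O)c1ccc2c(c1)OCCO2` stands at the higher end of the two numbers so far: in a functional assay on cells (Cancer cell lines, Homo sapiens) for inhibition, read by MTT assay, with a stated time of 48 h (on this read-out higher numbers stand for weaker inhibition and lower numbers for stronger inhibition), compound 2 gives 7710 nM, while compound 1 `COc1ccc(/C=C/C(=O)NNC(=O)c2ccc3c(c2)OCCO3)cc1` gives 930 nM. Within the data shown here, the one measured step is an 8.3-fold higher number from compound 1 to compound 2 (0.92 log units; beyond the scatter), a change of the whole aryl group rather than of a single substituent, so it bears only loosely on what follows. Compound 3 `O=C(/C=C/c1ccccc1Br)NNC(=O)c1ccc2c(c1)OCCO2` differs from compound 2 by bromo in place of methyl on an aromatic carbon. Among the measured compounds shown here, no measured pair shows this exchange, so the only guide is that both compounds carry the same core and that compound 2 sits where it does in this assay. The expectation is a step of a 1.3-fold lower number from compound 2 to compound 3 (0.11 log units; within the scatter), small enough to lie within the scatter, with no clear direction. Compound 3 is accordingly expected to give about 6000 nM in this assay, with the range estimated as 2000 nM to 20000 nM.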

Compound 3, half-maximal inhibitory concentration: 2110 nM
Compound 3: the middle estimate sits 2.8-fold (0.45 log units) above what was measured, within the range that was stated.
By their numbers in this assay, from the lowest: compound 1; then compound 3; then compound 2.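

In this assay, within the data shown here, bromo in place of methyl on an aromatic carbon ortho to a large group gives a 3.7-fold lower number from compound 2 to compound 3 (0.56 log units; beyond the scatter), the first step that exchanges a single substituent, and it shows that the read-out responds to the group at this place. The 2-bromophenyl group closes only part of the gap to the 4-methoxyphenyl group, with a 2.3-fold higher number from compound 1 to compound 3 (0.36 log units; beyond the scatter), a step that again changes the whole aryl group. Nothing available explains the difference between bromo and methyl here.

Going by these compounds, it remains open whether the lower number is specific to bromo or would also appear with another group on the same aromatic carbon, such as chloro, hydroxyl or an amine. On these data alone, it is also open whether bromo would give a similar step elsewhere on the six-membered aromatic ring.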